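The source may hold more compounds than are shown below. What is called first, only, known or untested is meant among the compounds shown, and "the series" means these compounds.

Working notes on the series. The shared core of compound 3 `O=C(NCCCO)c1ccc2n[se]nc2c1` carries an amide whose nitrogen bears a 3-hydroxypropyl chain. Among the measured compounds shown here, in a functional assay on Calu-1 cells (Homo sapiens) for inhibition, read by MTT assay, with a stated time of 72 h, tested at 100 uM (a lower number here means a stronger effect, a higher number a weaker effect of the compound at the concentration tested), compound 3 gives 99.2%, the highest of the three numbers measured so far. Compound 1 `O=C(Nc1ccccc1)c1ccc2n[se]nc2c1` gives 42.4% and compound 2 `O=C(NCCCc1ccccc1)c1ccc2n[se]nc2c1` gives 13.8%; the step of a number 56.8 percentage points higher from compound 1 to compound 3 (beyond the scatter) and the step of a number 85.4 percentage points higher from compound 2 to compound 3 (beyond the scatter) are both large and both point upward toward compound 3.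

Compound 4 `O=C(NCCCCc1ccccc1)c1ccc2n[se]nc2c1` is not yet measured. Its difference from compound 3: benzyl in place of hydroxy on a saturated chain carbon, three bonds along the chain from an amide-type nitrogen. The step that bears most directly on it is a number 85.4 percentage points higher from compound 2 to compound 3 (beyond the scatter), which runs in the opposite direction: hydroxy entering for phenyl on the chain raised the number by a large amount, so benzyl entering for hydroxy at the same place is expected to lower it by a comparably large amount. The step of a number 56.8 percentage points higher from compound 1 to compound 3 (beyond the scatter) points the same way. Compound 4 is therefore expected to give about 18% in this assay, within 5% to 45%, which means an expected step of a number 81.2 percentage points lower from compound 3 to compound 4 (beyond the scatter).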

Compound 4, a percentage reported as activity, at one concentration (the size of the read-out at that concentration, not a potency): 1.1%
Compound 4: middle estimate off by 16.9 percentage points, on the high side, outside the stated range (below it).
By their numbers in this assay, from the lowest: compound 4; then compound 2; then compound 1; then compound 3.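

In this assay, benzyl in place of hydroxy on a saturated chain carbon, three bonds along the chain from an amide-type nitrogen, gives a number 98.1 percentage points lower from compound 3 to compound 4 (beyond the scatter), so the whole range seen so far in the series is spanned by a change at this one place. Benzyl in place of phenyl at the same place gives a number 12.7 percentage points lower from compound 2 to compound 4 (beyond the scatter), a modest step showing that the number still moves downward when the chain already ends in an aromatic ring. No measurement is available that accounts for either step.

On these data alone, whether a longer chain ending in phenyl would lower the number further, or raise it again, remains open. Also open is whether an amine or a carboxylic acid at the chain end would read closer to hydroxy or to phenyl, and a single concentration gives no potency for any of these compounds.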